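Extending the Hydroxycarbamoyl Arm of Compound 2

A few compounds are considered here, and "the series" means these few. Any claim that something is new, unique, unknown or untested is made for them only; others in the source may bear on it.

compound 1 `COc1ccc(C(=O)c2ccc3c(ccn3Cc3ccc(C(=O)NO)cc3)c2)cc1OC` — 15.5 nM
compound 2 `COc1ccc(C(=O)c2ccc3c(ccn3Cc3ccc(C(=O)NO)cc3)c2)cc1` — 3.92 nM
compound 3 `O=C(NO)c1ccc(Cn2ccc3cc(C(=O)c4ccc(Cl)cc4)ccc32)cc1` — 6.73 nM

In an assay on isolated protein for inhibition of protein deacetylase HDAC6 (Homo sapiens) (a higher number here means a weaker inhibitor, a lower number a stronger inhibitor), compound 2 gives the lowest of the three numbers. The step of a 1.7-fold higher number from compound 2 to compound 3 (0.23 log units; within the scatter) lies within the scatter, whereas a 4.0-fold lower number from compound 1 to compound 2 (0.60 log units; beyond the scatter) and a 2.3-fold lower number from compound 1 to compound 3 (0.36 log units; beyond the scatter) lie beyond it.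

Compound 4 `COc1ccc(C(=O)c2ccc3c(ccn3Cc3ccc(/C=C/C(=O)NO)cc3)c2)cc1` differs from compound 2 by 2-(hydroxycarbamoyl)ethenyl in place of hydroxycarbamoyl on an aromatic carbon. Within the data shown here, none of the measured steps bears on this change: all three vary only the group on the carbonyl carbon and leave the hydroxycarbamoyl side untouched, so the expectation rests on the structural change alone and is uncertain. Compound 4 is expected to give about 5 nM, between 1.5 nM and 20 nM. This estimate corresponds to an expected step of a 1.3-fold higher number from compound 2 to compound 4 (0.11 log units; within the scatter), not clearly beyond the scatter.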

Compound 4, half-maximal inhibitory concentration: 108 nM
Beside the measured number, compound 4's estimate is 22-fold (1.33 log units) below it; the whole stated range lies below it.
By their numbers in this assay, from the lowest: compounds 2 and 3 (each within the scatter of the next); then compound 1; then compound 4.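

In this assay, the aromatic carbon para to a large group proves a sensitive position: 2-(hydroxycarbamoyl)ethenyl in place of hydroxycarbamoyl gives a 28-fold higher number from compound 2 to compound 4 (1.44 log units; beyond the scatter), the largest step in the series and the first to touch this side of the molecule. Nothing at hand gives a reason for a step of this size.

The compounds shown leave open whether a saturated two-carbon chain ending in hydroxycarbamoyl would behave like the ethenyl link. They also leave open whether a carboxylic acid could take the place of the hydroxycarbamoyl group on either arm.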